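The source may report more compounds than this note shows. Statements on the series, on what has been measured and on what is new or still open speak of the compounds shown alone.

Compound 1 `O=c1cc(N2CCN(CC3CCC(OS(=O)(=O)c4cccnc4)CC3)CC2)sc2c([N+](=O)[O-])cc(C(F)(F)F)cc12`, compound 2 `O=C(OC1CCC(CN2CCN(c3cc(=O)c4cc(C(F)(F)F)cc([N+](=O)[O-])c4s3)CC2)CC1)c1cccc(C(F)(F)F)c1` and compound 3 `O=C(OC1CCC(CN2CCN(c3cc(=O)c4cc(C(F)(F)F)cc([N+](=O)[O-])c4s3)CC2)CC1)c1cccc(F)c1` share one core and differ only in the group on an oxygen on a saturated carbon. In an ADME assay on Vero cells (Chlorocebus sabaeus) for cytotoxicity, read by MTT assay, with a stated time of 48 h (on this read-out higher numbers stand for weaker inhibition and lower numbers for stronger inhibition), compound 3 gives > 64 ug/mL, which is a limit of the assay and not a number. Compound 1 gives > 64 ug/mL, also a limit. Compound 2 gives > 64 ug/mL, again a limit. Compound 3 therefore has no exact standing among its neighbours, and the whole series sits at one mark: the limit of > 64 ug/mL in this assay, at which 3 of the 3 values shown sit.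

Compound 4 `O=C(OC1CCC(CN2CCN(c3cc(=O)c4cc(C(F)(F)F)cc([N+](=O)[O-])c4s3)CC2)CC1)c1ccco1` brings one change: furan-2-yl in place of 3-fluorophenyl on a carbonyl carbon. The measured steps that bear on it are a step that the two limits leave unreadable from compound 2 to compound 3, a step that the two limits leave unreadable from compound 1 to compound 3 and a step that the two limits leave unreadable from compound 1 to compound 2. None has a readable size, and none of the three compounds left the limit. In this assay no step beyond the usual scatter is therefore expected, in either direction, and the expected step is a step that the limit leaves unreadable from compound 3 to compound 4. For compound 4 the estimated value is 70 ug/mL, with an expected range from 32 ug/mL to 128 ug/mL.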

Compound 4, half-maximal inhibitory concentration: > 64 ug/mL
Compound 4: only a limit was reported; the forecaster's own chance of this, stated with the estimate: 85%; the middle value lies beyond the limit too.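

In this assay compound 4 gives > 64 ug/mL, a limit of the assay and not a number. Its steps from compound 1, compound 2 and compound 3 therefore cannot be read, and the series stays at one mark: the limit of > 64 ug/mL in this assay, at which 4 of the 4 values shown sit. The compounds shown leave open how far apart these four actually lie in this read-out.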